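Compound 3: replacing the ethylcarbamoyl group of compound 2

The source may report more compounds than this note shows. Statements on the series, on what has been measured and on what is new or still open speak of the compounds shown alone.

Within the data shown here, in a physicochemical assay for solubility, in phosphate buffer, measured as kinetic solubility, with a stated time of 1 h, at pH 7.4 (on this read-out lower numbers stand for lower solubility and higher numbers for higher solubility), two compounds have numbers so far. Compound 1 (`CNCC(=O)Nc1ccc(-c2nc(C(C)(C)S(C)(=O)=O)cc([C@]34CCOC[C@H]3C4)n2)cc1`) gives 217 ug/mL, and compound 2 (`CCNC(=O)Nc1ccc(-c2nc(C(C)(C)S(C)(=O)=O)cc([C@]34CCOC[C@H]3C4)n2)cc1`) gives 74 ug/mL, the lower of the two. Among the measured compounds shown here, the only measured step, a 2.9-fold lower number from compound 1 to compound 2 (0.47 log units; beyond the scatter), is modest but beyond the scatter. It places ethylamino in place of (methylamino)methyl on a carbonyl carbon.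

Compound 3 (`CC(C)(c1cc([C@]23CCOC[C@H]2C3)nc(-c2ccc(NC(=S)NCCO)cc2)n1)S(C)(=O)=O`) has not yet been measured. Its difference from compound 2 is a group of 6 heavy atoms (3 carbon, 1 nitrogen, 1 oxygen, 1 sulfur; no ring) in place of a group of 5 heavy atoms (3 carbon, 1 nitrogen, 1 oxygen; no ring), on a nitrogen on an aromatic ring: ethylcarbamoyl leaves and a group with no common name enters, on a nitrogen on an aromatic ring. The measured step is a different change at a different place, so it offers only a rough size and no direction. For the measured compounds named here, no measured pair shows this replacement, and a small upward move in this assay is only a working assumption. The expected move is a 1.2-fold higher number from compound 2 to compound 3 (0.09 log units; within the scatter), which is not expected to go clearly beyond the scatter. Compound 3 is estimated at 90 ug/mL, with an expected range of 30 ug/mL to 220 ug/mL.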

Compound 3, solubility: 173 ug/mL
Compound 3: middle estimate off by 1.9-fold (0.28 log units), on the low side; measured number inside the range.
By their numbers in this assay, from the lowest: compound 2; then compounds 3 and 1 (each within the scatter of the next).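

In this assay, compound 1 and compound 2 showed only a replacement on the carbonyl carbon, whereas the new result shows that a sulfur-bearing group of 6 heavy atoms can take the place of ethylcarbamoyl on a nitrogen on an aromatic ring, with a 2.3-fold higher number from compound 2 to compound 3 (0.37 log units; beyond the scatter) as the measured move. Among these compounds, the same group, with 2 hydrogen-bond donors and 2 hydrogen-bond acceptors, gives a 1.3-fold lower number from compound 1 to compound 3 (0.10 log units; within the scatter) as its step against the group on the nitrogen in compound 1, so ethylcarbamoyl is not the only group tolerated at this place without loss on this read-out. No measurement shown here bears on what lies behind either step.

The entering group differs from ethylcarbamoyl in more than one atom, so the share of the sulfur and the share of the rest of the chain cannot be separated with these compounds. As far as these compounds go, the same group with a carbonyl oxygen in place of the sulfur would split the two, and a longer chain, an amine or a carboxylic acid on this nitrogen remains open.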